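The source may report more compounds than this note shows. Statements on the series, on what has been measured and on what is new or still open speak of the compounds shown alone.

Going by the values given here, compound 2 `O=C(O)/C=C/c1ccc(/C(=C(/CCF)c2ccccc2)c2ccc3[nH]ncc3c2)cc1` holds the lower of the two numbers measured so far: in a functional assay on MCF7 cells (Homo sapiens) for cytotoxicity, read by CellTiter-Glo, with a stated time of 5 days (on this read-out higher numbers stand for weaker inhibition and lower numbers for stronger inhibition), compound 2 gives 2.1 nM, whereas compound 1 `C/C(=C(/c1ccc(/C=C/C(=O)O)cc1)c1ccc2[nH]ncc2c1)c1ccccc1` gives 40 nM. Compound 3 `O=C(O)/C=C/c1ccc(/C(=C(\c2ccccc2)C(F)(F)F)c2ccc3[nH]ncc3c2)cc1` differs from compound 2 by trifluoromethyl in place of 2-fluoroethyl on a double-bonded chain carbon bound to an aromatic carbon and a double-bonded chain carbon. Among the compounds with values here, the one measured step, a 19-fold lower number from compound 1 to compound 2 (1.28 log units; beyond the scatter), concerns a different fluorine-bearing group and bears on the present change only loosely, so it gives no firm direction. The step of a 1.9-fold higher number from compound 2 to compound 3 (0.28 log units; within the scatter) is therefore expected to be modest, if any. Compound 3 is estimated at 4 nM, within the range 1 nM to 15 nM.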

Compound 3, half-maximal inhibitory concentration: 5.5 nM
For compound 3 the middle estimate is 1.4-fold (0.14 log units) below the measured one; low and high end bracket the measured number.
By their numbers in this assay, from the lowest: compound 2; then compound 3; then compound 1.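

In this assay trifluoromethyl at this place also gives a lower number than methyl, with a 7.3-fold lower number from compound 1 to compound 3 (0.86 log units; beyond the scatter) showing that the gain does not depend on 2-fluoroethyl alone. Even so, a 2.6-fold higher number from compound 2 to compound 3 (0.42 log units; beyond the scatter) shows that trifluoromethyl does not quite match 2-fluoroethyl, so the two fluorine-bearing groups are not interchangeable here. No measurement available here explains either difference. Whether the trend reflects the fluorine atoms or the group itself stays open, since plain ethyl is absent from the compounds shown. Going by these compounds, how a nitrile or a longer chain would behave at this place also remains unknown.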